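The source may report more compounds than this note shows. Statements on the series, on what has been measured and on what is new or still open speak of the compounds shown alone.

Measured compounds in a functional assay on DU-145 cells (Homo sapiens) for cytotoxicity, read by MTT assay, with a stated time of 24 h; a lower number here means a stronger inhibitor, a higher number a weaker inhibitor:
compound 1 `NNC(=O)Cn1nc(N)c2c(C(F)(F)F)cc(-c3ccccc3)nc21`, for which compound 1 gives 52400 nM;
compound 2 `Nc1nn(CC(=O)NCCO)c2nc(-c3ccccc3)cc(C(F)(F)F)c12`, for which compound 2 gives 96300 nM;
compound 3 `Nc1nn(CC(=O)NC2CC2)c2nc(-c3ccccc3)cc(C(F)(F)F)c12`, for which compound 3 is reported as "not active" (no number reported).

Compound 2 holds the higher of the two numbers reported, but the step of a 1.8-fold higher number from compound 1 to compound 2 (0.26 log units; within the scatter) lies within the scatter, so no order between compounds 1 and 2 can be read from it. Compound 3 is reported without a single number.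

Compound 4 `Nc1nn(CC(=O)N2CCOCC2)c2nc(-c3ccccc3)cc(C(F)(F)F)c12` differs from compound 2 by morpholin-4-yl in place of (2-hydroxyethyl)amino on a carbonyl carbon. Within the data shown here, no measured step matches this change. Among the measured compounds shown here, the only step at hand, a 1.8-fold higher number from compound 1 to compound 2 (0.26 log units; within the scatter), exchanges one group for another on an amide-type nitrogen and stays within the scatter, while compound 3, which carries yet another amide substituent, is reported as not active. Every compound with a number here is weak, and the third gives none. The estimate for compound 4 is therefore placed close to compound 2, with the step of a 1.1-fold higher number from compound 2 to compound 4 (0.06 log units; within the scatter) expected to stay within the scatter, and with a real chance that only a limit is reported. Compound 4 is expected at 110000 nM, in the range 40000 nM to 300000 nM.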

Compound 4, half-maximal inhibitory concentration: 5100 nM
For compound 4 the middle estimate is 22-fold (1.33 log units) above the measured one, outside the stated range (below it).
By their numbers in this assay, from the lowest: compound 4; then compounds 1 and 2 (each within the scatter of the next).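

In this assay the group on this carbonyl carbon proves able to move the number: morpholin-4-yl in place of (2-hydroxyethyl)amino gives a 19-fold lower number from compound 2 to compound 4 (1.28 log units; beyond the scatter) and morpholin-4-yl in place of aminoamino gives a 10-fold lower number from compound 1 to compound 4 (1.01 log units; beyond the scatter). Both steps lie beyond the scatter, whereas the step between the two earlier compounds with numbers did not, so the exchange of this amide group is the first change shown here to have a large effect. Nothing among the data shown offers an explanation for this effect.

The compounds shown leave open whether the ring of morpholin-4-yl or the missing amide hydrogen goes with the lower number. A piperidin-1-yl or a dimethylamino group on the same carbonyl carbon would separate these two readings.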